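The source may report more compounds than this note shows. Statements on the series, on what has been measured and on what is new or still open speak of the compounds shown alone.

Measured so far in this series:
compound 1 `O=C(Cn1nnc(-c2ccccc2)n1)NC1CC2CCC1C2`: 1980 nM
compound 2 `Cc1cc(NC(=O)Cn2nnc(-c3cccc(Cl)c3)n2)n(C2CCCCC2)n1`: 300 nM

Two compounds carry numbers in an assay on HEK293 cells for activation of Kir3.1/Kir3.2 (Homo sapiens), read by thallium flux; on this read-out lower numbers stand for an effect already at smaller amounts and higher numbers for an effect only at larger amounts of compound. Compound 2 gives 300 nM, the lowest of the two, and compound 1 gives 1980 nM, a higher number; the gap between the two lies beyond the scatter, so compound 2 stands as the stronger of the pair as measured.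

Compound 3 `Cc1cc(NC(=O)Cn2nnc(-c3cccc(F)c3)n2)n(C2CCCCC2)n1` differs from compound 2 in one place only: fluoro in place of chloro on an aromatic carbon. For the measured compounds named here, no measured pair shows this change, so its size is not fixed by anything already in hand. The expectation is a modest move toward a higher number, of a size that may or may not clear the scatter, since compound 2 sits at 300 nM and the change is confined to one halogen. The expected step of a 2.3-fold higher number from compound 2 to compound 3 (0.37 log units; beyond the scatter) is toward a higher number. Compound 3 is therefore estimated at 700 nM, with a range from 300 nM to 1800 nM.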

Compound 3, half-maximal effective concentration: 81 nM
Compound 3: middle estimate off by 8.6-fold (0.94 log units), on the high side; measured number below the stated range.
By their numbers in this assay, from the lowest: compound 3; then compound 2; then compound 1.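

At the place on the aromatic ring meta to a large group, the choice of halogen matters: in this assay, 3-chlorophenyl to 3-fluorophenyl gives a 3.7-fold lower number from compound 2 to compound 3 (0.57 log units; beyond the scatter), a step beyond the scatter. One heavy atom replaces one heavy atom, with no ring, hydrogen-bond donor, hydrogen-bond acceptor or net charge entering or leaving, so even a change this small registers on the read-out. No measurement in hand bears on why the step has this direction or size.

The compounds shown compare only chloro and fluoro, at this one place and on one shared core. On these data alone, how a nitrile, a methoxy group or a hydrogen at the same place would compare with fluoro remains open, as does whether the step would carry over to a different amide partner.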